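The source may report more compounds than this note shows. Statements on the series, on what has been measured and on what is new or still open speak of the compounds shown alone.

Measured compounds:
Compound 1 `CC1(C)[C@H]2CC[C@]1(C)N(Cc1cn(-c3ccccc3Cl)nn1)C(=O)C2` gives 70 nM in a functional assay on A549 cells (Homo sapiens) for inhibition, read by MTT assay, with a stated time of 24 h; on this read-out lower numbers stand for stronger inhibition and higher numbers for weaker inhibition.
Compound 2 `Cc1ccc(-n2cc(CN3C(=O)C[C@@H]4CC[C@@]3(C)C4(C)C)nn2)cc1` gives 400 nM in this assay.

Compound 1 gives the lowest of the two numbers in this assay; its nearest neighbour is compound 2, and the step of a 5.7-fold higher number from compound 1 to compound 2 (0.76 log units; beyond the scatter) lies beyond the scatter. Compound 3 `CC1(C)[C@H]2CC[C@]1(C)N(Cc1cn(-c3cccc(Br)c3)nn1)C(=O)C2` is not yet measured. It differs from compound 1 by 3-bromophenyl in place of 2-chlorophenyl on an aromatic nitrogen.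

Among the compounds with values here, only one measured step speaks to a change at this aromatic nitrogen: a 5.7-fold higher number from compound 1 to compound 2 (0.76 log units; beyond the scatter), where 4-methylphenyl replaced 2-chlorophenyl and the number rose modestly. Compound 3 keeps a halogen-bearing phenyl but places the halogen elsewhere, so the expectation for compound 3 in this assay is a small to modest rise, a 2.1-fold higher number from compound 1 to compound 3 (0.33 log units; beyond the scatter), less than that seen for compound 2. Compound 3 is therefore estimated at 150 nM, with a range from 60 nM to 400 nM.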

Compound 3, half-maximal inhibitory concentration: 90 nM
Compound 3: middle estimate off by 1.7-fold (0.22 log units), on the high side; the range from low to high includes it.
By their numbers in this assay, from the lowest: compounds 1 and 3 (each within the scatter of the next); then compound 2.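

In this assay, the exchange of 2-chlorophenyl for 3-bromophenyl gives a 1.3-fold higher number from compound 1 to compound 3 (0.11 log units; within the scatter), so a number at this level on this aromatic nitrogen does not depend on 2-chlorophenyl alone. Set against 4-methylphenyl, 3-bromophenyl gives a 4.4-fold lower number from compound 2 to compound 3 (0.65 log units; beyond the scatter), which shows that the rise seen with compound 2 is not a general result of leaving 2-chlorophenyl, and among these three compounds only compound 2 stands apart. Nothing given here accounts for this difference between the groups.

As far as these compounds go, compound 3 changes both the halogen and its place on the phenyl ring, so the share of each stays open, and 3-chlorophenyl or 2-bromophenyl would separate them. Also open, from the compounds shown here alone, is how an amine or a carboxylic acid on this phenyl ring, or a longer chain in its stead, would read out.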